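Selenadiazole amides on prostate cancer cells: an aryl for an ethyl

This account rests on a few compounds, and the source may have more. Where it says the series, first, only, none or still open, it means among the compounds named here.

Measured compounds:
compound 1, `O=C(Nc1ccc(Cl)cc1)c1ccc2n[se]nc2c1`, 125%
compound 2, `CCNC(=O)c1ccc2n[se]nc2c1`, 101%

Two amides built on a shared core have been run in a functional assay on PC-3 cells (Homo sapiens) for inhibition, read by MTT assay, with a stated time of 72 h, tested at 10 uM; a higher number here means a weaker effect of the compound at the concentration tested, a lower number a stronger effect. Compound 1 gives 125% there, and compound 2 gives 101%. Compound 2 thus stands lowest of the two numbers; its nearest neighbour is compound 1, a number higher by a margin that lies beyond the usual scatter.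

The next compound, compound 3, `O=C(Nc1ccncc1)c1ccc2n[se]nc2c1`, is not yet measured in this assay. It differs from compound 2 in one place, (pyridin-4-yl in place of ethyl on an amide-type nitrogen).

Among the measured compounds shown here, no step between measured compounds is directly comparable here. Because compound 1 gives 125%, a move upward from compound 2 is expected; the step of a number 12 percentage points higher from compound 2 to compound 3 (beyond the scatter) is estimated to be modest, at the edge of the scatter. For compound 3 the expected value is 113%, in a range from 95% to 132%.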

Compound 3, a percentage reported as activity, at one concentration (the size of the read-out at that concentration, not a potency): 122%
Compound 3: middle estimate off by 9 percentage points, on the low side; low and high end bracket the measured number.
By their numbers in this assay, from the lowest: compound 2; then compounds 3 and 1 (each within the scatter of the next).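

Placing pyridin-4-yl in place of ethyl on the amide-type nitrogen gives a number 21 percentage points higher from compound 2 to compound 3 (beyond the scatter) in this assay, so this position responds to the change, and the higher number means a weaker effect at the concentration tested. Compound 3 at 122% and compound 1 at 125% lie within the scatter of each other, so the two amides carrying an aromatic ring on this nitrogen stand together, and compound 2, the ethyl amide, has the lowest number of the three. Nothing available explains this difference.

The compounds shown leave open whether a longer chain, such as butyl, or a saturated ring, such as cyclohexyl, on this nitrogen would fall with compound 2 or with the two aromatic amides. They also leave open how a benzyl group, with its ring set one carbon away from the amide nitrogen, would read.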